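Replacing the aryl group of compound 2

This account rests on a few compounds, and the source may have more. Where it says the series, first, only, none or still open, it means among the compounds named here.

Measured in a toxicity assay on HeLa cells (Homo sapiens) for cytotoxicity, read by MTT assay, with a stated time of 3 h; a higher number here means a weaker inhibitor, a lower number a stronger inhibitor:
Compound 1 `COc1ccc(C2=[N+]3C(=Nc4c(-c5ccccc5)c5c(n4[B-]3(F)F)-c3ccc(OC)cc3CC5)C(c3ccccc3)=C2Br)cc1`: > 50000 nM, a limit
Compound 2 `COc1ccc(C2=[N+]3C(=Nc4c(-c5ccccc5)c5c(n4[B-]3(F)F)-c3ccc(OC)cc3CC5)C(c3ccccc3)=C2I)cc1`: > 50000 nM, a limit

Compound 2 stands only at its limit of > 50000 nM, with no number known. Going by the values given here, the sole measured step, a step that the two limits leave unreadable from compound 1 to compound 2, bears on the next change only loosely, and the whole evidence is the limit of > 50000 nM in this assay, at which 2 of the 2 values shown sit. Compound 3 `COc1ccc2c(c1)CCc1c(-c3ccccc3)c3n(c1-2)[B-](F)(F)[N+]1=C(c2ccc(C)s2)C(I)=C(c2ccccc2)C1=N3` carries 5-methylthiophen-2-yl in place of 4-methoxyphenyl on a carbon with a double bond to nitrogen. No change beyond the scatter is expected in this assay, in either direction. The expected step is a step that the limit leaves unreadable from compound 2 to compound 3. For compound 3 the estimate is 60000 nM, within an expected range of 25000 nM to 100000 nM.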

Compound 3, half-maximal inhibitory concentration: > 50000 nM
Compound 3 gave a limit, no number (the forecaster's own chance of this, stated with the estimate: 85%); the middle value lies beyond the limit too.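

Going by these compounds alone, compound 2 and compound 3 both stop at a limit in this assay, and no step between them can be read. The compounds shown leave open whether 5-methylthiophen-2-yl in place of 4-methoxyphenyl changes the inhibitory concentration at all.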